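The source may report more compounds than this note shows. Statements on the series, on what has been measured and on what is new or still open speak of the compounds shown alone.

Three compounds sharing one core were examined in an ADME assay on MT4 cells (Homo sapiens) for cytotoxicity, read by MTT assay, with a stated time of 4 days; a higher number here means that more compound is tolerated, a lower number that less compound is tolerated. Compound 1 `CCOc1cc(C#N)cc(OCC)c1Oc1nc(Nc2ccc(C#N)cc2)nc2ccccc12` gives 108000 nM in this assay. Compound 2 `COc1cc(C#N)ccc1Oc1nc(Nc2ccc(C#N)cc2)nc2ccccc12` reaches only a limit of this assay, reported as >= 140000 nM. Compound 3 `CCCOc1cc(C#N)cc(OCC)c1Oc1nc(Nc2ccc(C#N)cc2)nc2ccccc12` gives 123000 nM in this assay, the highest of the two numbers shown, with compound 1 as its nearest neighbour; the step of a 1.1-fold higher number from compound 1 to compound 3 (0.06 log units; within the scatter) stayed within the scatter.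

Compound 4 `CCCOc1cc(C#N)cc(OC)c1Oc1nc(Nc2ccc(C#N)cc2)nc2ccccc12` has not yet been measured in this assay. It differs from compound 3 by hydrogen in place of methyl on a saturated chain carbon bound to an oxygen on an aromatic ring, a change of the same kind as the one measured, on the other chain and in the opposite direction. Within the data shown here, the only measured step that bears on it is a 1.1-fold higher number from compound 1 to compound 3 (0.06 log units; within the scatter), and it was small. Because of a 1.1-fold higher number from compound 1 to compound 3 (0.06 log units; within the scatter) no step beyond the scatter is expected in this assay for compound 4, in either direction. The one limit seen, (the limit of >= 140000 nM in this assay, at which 1 of the 3 values shown sits), shows that a value in this region can also return only as a limit. Compound 4 is therefore estimated at 115000 nM, between 60000 nM and 220000 nM. The expected step from compound 3 is a 1.1-fold lower number from compound 3 to compound 4 (0.03 log units; within the scatter).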

Compound 4, half-maximal cytotoxic concentration: 5200 nM
Estimate against measurement, compound 4: 22-fold (1.34 log units) above, outside the stated range (below it).
By their numbers in this assay, from the lowest: compound 4; then compounds 1 and 3 (each within the scatter of the next). At a limit, above all of these: compound 2.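

In this assay, shortening ethoxy to methoxy while the propoxy stays gives a 24-fold lower number from compound 3 to compound 4 (1.37 log units; beyond the scatter), so one chain carbon at this place can matter greatly, which the step from ethoxy to propoxy, a 1.1-fold higher number from compound 1 to compound 3 (0.06 log units; within the scatter), did not reveal. Methoxy alone does not bring the number down either, since propoxy in place of hydrogen on an aromatic carbon gives an at least 26-fold lower number from compound 2 to compound 4 (1.43 log units; beyond the scatter). That step starts from a limit, the one held by compound 2: the limit of >= 140000 nM in this assay, at which 1 of the 4 values shown sits.

The compounds shown leave open whether the low number belongs specifically to propoxy paired with methoxy, or would also appear with a butoxy chain or an amine in place of the propoxy. They also leave open whether a hydroxyl in place of the methoxy would keep the number low.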